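The source may hold more compounds than are shown below. What is called first, only, known or untested is meant among the compounds shown, and "the series" means these compounds.

Measured compounds:
Compound 1, `CCOC(=O)[C@@H]1CCCN(S(=O)(=O)c2ccc(S(=O)(=O)N3CCOCC3)cc2)C1`: in a functional assay on BXPC-3 cells (Homo sapiens) for inhibition, read by MTT assay, with a stated time of 7 days (a lower number here means a stronger inhibitor, a higher number a weaker inhibitor), compound 1 gives 23400 nM.
Compound 2, `CCOC(=O)[C@@H]1CCCN(S(=O)(=O)c2ccc(S(=O)(=O)N3CCCCC3)cc2)C1`: in this assay compound 2 gives 3300 nM.

Going by the values given here, compound 2 stands at the lower of the two numbers, and the single measured step, a 7.1-fold lower number from compound 1 to compound 2 (0.85 log units; beyond the scatter), separates it from compound 1. Compound 3, `CCOC(=O)[C@@H]1CCCN(S(=O)(=O)c2ccc(S(=O)(=O)N(C)Cc3ccccc3)cc2)C1`, differs from compound 2 by benzyl(methyl)amino in place of piperidin-1-yl on a sulfonyl sulfur. Among the compounds with values here, the only step that bears on this change is the one from compound 1 to compound 2, which also exchanged the amine on that sulfonyl sulfur and gave a modest step; compound 3, however, replaces the ring with an open-chain amine carrying a benzyl group, for which no measured pair gives guidance. The expectation for compound 3 is therefore a step of a 1.4-fold higher number from compound 2 to compound 3 (0.13 log units; within the scatter) in this assay, near the scatter, with an estimated value of 4500 nM and a range from 1200 nM to 17000 nM.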

Compound 3, half-maximal inhibitory concentration: > 30000 nM
Compound 3: a limit, no number (the forecaster's own chance of this, stated with the estimate: 5%); middle value at least 6.6-fold (0.82 log units) from the limit.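

Compound 3 gives no number in this assay, only a limit: the limit of > 30000 nM in this assay, at which 1 of the 3 values shown sits. On the sulfonyl sulfur, benzyl(methyl)amino in place of piperidin-1-yl gives an at least 9.0-fold higher number from compound 2 to compound 3 (0.95 log units; beyond the scatter), which shows that this position does not tolerate every amine and that the gain seen with piperidin-1-yl does not carry over to this open-chain amine. The comparison with morpholin-4-yl gives an at least 1.2-fold higher number from compound 1 to compound 3 (0.10 log units; that floor lies within the scatter), and with its floor within the scatter, it leaves the order of those two compounds unsettled.

The compounds shown do not separate the effect of opening the ring from that of adding the benzyl group, which a dimethylamino group or a pyrrolidin-1-yl ring on the same sulfur could address. They also leave open whether a carboxylic acid in place of the ethyl ester would change the picture.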